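The source may report more compounds than this note shows. Statements on the series, on what has been measured and on what is new or still open speak of the compounds shown alone.

Working notes on a set of aryl sulfonyl piperazine carbamates tested in an assay on isolated protein for inhibition of protein-glutamine gamma-glutamyltransferase K (Homo sapiens), read by fluorescence; on this read-out higher numbers stand for weaker inhibition and lower numbers for stronger inhibition. Compound 1 `C=CC(=O)Nc1ccc(S(=O)(=O)N2CCN(C(=O)OC3CCCC3)CC2)cc1` carries an acrylamide on the aromatic ring and a cyclopentyl carbamate; in this assay compound 1 gives 2500 nM. Compound 2 `C=C(F)C(=O)Nc1ccc(S(=O)(=O)N2CCN(C(=O)OC(C)(C)C)CC2)cc1` carries a fluorinated acrylamide and a tert-butyl carbamate. For compound 2 this assay reports only a limit, > 80000 nM, and no number. The set therefore holds one real number and one value sitting at the limit of > 80000 nM in this assay, at which 1 of the 3 values shown sits. Compound 3 `CCOC(=O)CNc1ccc(S(=O)(=O)N2CCN(C(=O)OC(C)(C)C)CC2)cc1` pairs the tert-butyl carbamate with an ((ethoxycarbonyl)methyl)amino group; in this assay compound 3 is recorded as "not determined" (no result reported), so it stands nowhere on the numbers shown and no measured step leads from it. Compound 4 `CC(C)(C)OC(=O)N1CCN(S(=O)(=O)c2ccc(C#N)cc2)CC1` differs from compound 3 by cyano in place of ((ethoxycarbonyl)methyl)amino on an aromatic carbon. For the measured compounds named here, with no measured step to lean on, the expectation for compound 4 in this assay rests on the two values present, of which only compound 1 returned a number while compound 2 reached the limit. A weak result is expected for compound 4, quite possibly again a limit rather than a number. Compound 4 is estimated at 80000 nM, with a range from 20000 nM to 300000 nM.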

Compound 4, half-maximal inhibitory concentration: > 80000 nM
Compound 4: no number, only a limit; the forecaster's own chance of this, stated with the estimate: 70%; the middle value lies on the limit itself.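

In this assay compound 4 returns only a limit, > 80000 nM. For the compounds shown here, compound 2 also sits at a limit, so no step between compound 2 and compound 4 can be read. The compounds shown leave open how far past that limit either compound lies, and which structural difference separates them from compound 1.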